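The source may hold more compounds than are shown below. What is called first, only, known or untested is meant among the compounds shown, and "the series" means these compounds.

Going by the values given here, in an ADME assay on MDCKII-LE cells (Canis lupus familiaris) for permeability (a lower number here means that the compound crosses the layer more slowly, a higher number that the compound crosses the layer faster), compound 3 `Cc1ccc(Oc2cc(C(=O)Nc3cnc(C)cn3)cc3oc(C)cc23)cc1` stands lowest of the three compounds measured so far, at 0.3 10^-6 cm/s. Compound 4 `Cc1cnc(NC(=O)c2cc(Oc3ccc(C(=O)N(C)C)cc3)c3cc(C)oc3c2)cn1` differs from it by dimethylcarbamoyl in place of methyl on an aromatic carbon, on a six-membered aromatic ring of carbon only, para to a large group (dimethylcarbamoyl in place of methyl on an aromatic carbon). Dimethylcarbamoyl is also present in compound 1 `Cc1cnc(NC(=O)c2cc(Oc3cnc(C(=O)N(C)C)cn3)c3cc(C)oc3c2)cn1`, at 22.3 10^-6 cm/s, and in compound 2 `Cc1cnc(NC(=O)c2cc(Oc3cnc(C(=O)N(C)C)nc3)c3cc(C)oc3c2)cn1`, at 20.1 10^-6 cm/s. Among the compounds with values here, a rise beyond the scatter is therefore expected in this assay, although the ring carrying the group differs and no measured pair isolates this change. The expected size is a 40-fold higher number from compound 3 to compound 4 (1.60 log units; beyond the scatter). For compound 4 the estimated value is 12 10^-6 cm/s, within a range of 3 10^-6 cm/s to 30 10^-6 cm/s.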

Compound 4, apparent permeability: 5.9 10^-6 cm/s
The estimate for compound 4 lay 2.0-fold (0.31 log units) above the measured number; measured number inside the range.
By their numbers in this assay, from the lowest: compound 3; then compound 4; then compounds 2 and 1 (each within the scatter of the next).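

Read in this assay as a single change, dimethylcarbamoyl in place of methyl gives a 20-fold higher number from compound 3 to compound 4 (1.29 log units; beyond the scatter) on a six-membered aromatic ring of carbon only, para to a large group. This pair isolates the change, and it shows a large step at this position with no nitrogen in that ring. Nothing measured here gives a reason for the step.

Going by these compounds, whether another group at this place, such as an amine or a carboxylic acid, would give a step of like size stays open. So does whether the same exchange would give such a step on the rings carried by compound 1 and compound 2.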